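The source may hold more compounds than are shown below. What is called first, only, known or untested is meant among the compounds shown, and "the series" means these compounds.

Measured compounds:
compound 1 `COc1cc(N(Cc2ccc(C)cc2)C(=O)CSc2nc3ccccc3s2)cc(OC)c1OC`: 54200 nM
compound 2 `COc1ccc(CN(C(=O)CSc2nc3cc(Cl)ccc3s2)c2cc(OC)c(OC)c(OC)c2)cc1O`: 85 nM
compound 3 `COc1ccc(CN(C(=O)CSc2nc3c(C)cccc3s2)c2cc(OC)c(OC)c(OC)c2)cc1O`: 493 nM

In a functional assay on MGC-803 cells (Homo sapiens) for antiproliferative activity, read by MTT assay, with a stated time of 48 h (on this read-out higher numbers stand for weaker inhibition and lower numbers for stronger inhibition), compound 1 gives 54200 nM, the highest of the three numbers; compound 2 gives 85 nM and compound 3 gives 493 nM, both far lower, beyond the scatter. Compound 2 and compound 3 differ from compound 1 in two places at once, on the benzyl and on the group attached to the sulfur, so their gap to compound 1 cannot be split into parts. Within the data shown here, the one single-site step available, a 5.8-fold higher number from compound 2 to compound 3 (0.76 log units; beyond the scatter), concerns the group on the sulfur and not the benzyl, so it does not bear on the change to compound 4.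

Compound 4 `COc1ccc(CN(C(=O)CSc2nc3ccccc3s2)c2cc(OC)c(OC)c(OC)c2)cc1Br` keeps the unsubstituted group on the sulfur of compound 1 and changes only the benzyl: 3-bromo-4-methoxyphenyl in place of 4-methylphenyl on a saturated chain carbon bound to an amide-type nitrogen. Among the measured compounds shown here, compound 2 and compound 3 both carry a 4-methoxybenzyl with a small substituent at the 3-position and both sit far below compound 1, which supports expecting a large drop in number for compound 4, though no measured pair isolates this change and the bromine differs from the hydroxyl of those two. Compound 4 is expected to give about 1500 nM in this assay, a step of a 36-fold lower number from compound 1 to compound 4 (1.56 log units; beyond the scatter), with a range of 200 nM to 12000 nM.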

Compound 4, half-maximal inhibitory concentration: 852 nM
For compound 4 the middle estimate is 1.8-fold (0.25 log units) above the measured one, and the stated range covers the measured number.
By their numbers in this assay, from the lowest: compound 2; then compounds 3 and 4 (each within the scatter of the next); then compound 1.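

In this assay, 3-bromo-4-methoxyphenyl in place of 4-methylphenyl on a saturated chain carbon bound to an amide-type nitrogen gives a 64-fold lower number from compound 1 to compound 4 (1.80 log units; beyond the scatter), with the group on the sulfur unchanged. This isolates the benzyl as a site where one change alone moves the number by a large step, which compound 2 and compound 3 could not show, as each differs from compound 1 in two places at once. No measurement at hand bears on the cause of this step.

The compounds shown leave open how the step divides between the bromine and the methoxy, and whether an amine or a carboxylic acid in place of the bromine would give a similar number. Going by these compounds, whether the step keeps its size with the chlorine-bearing group on the sulfur of compound 2 also stays open.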